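The source may report more compounds than this note shows. Statements on the series, on what has been measured and on what is new or still open speak of the compounds shown alone.

Compound 1 `CC(C)C(=O)Nc1c(C(O)(C(F)(F)F)C(F)(F)F)ccc2ccccc12`: 6630 nM
Compound 2 `N#Cc1cccc(C(=O)Nc2c(C(O)(C(F)(F)F)C(F)(F)F)ccc3ccccc23)c1`: 12 nM

Among the measured compounds shown here, in an assay on LtK cells with ATP-sensitive inward rectifier potassium channel 11 (Homo sapiens) as the target (on this read-out lower numbers stand for an effect already at smaller amounts and higher numbers for an effect only at larger amounts of compound), compound 2 holds the lower of the two numbers; its only neighbour, compound 1, lies far above it, as a 550-fold lower number from compound 1 to compound 2 (2.74 log units; beyond the scatter) shows. Compound 3 `O=C(Nc1c(C(O)(C(F)(F)F)C(F)(F)F)ccc2ccccc12)c1ccc(Br)cc1` is not yet measured and differs from compound 2 in one place: 4-bromophenyl in place of 3-cyanophenyl on a carbonyl carbon. For the measured compounds named here, the only measured step, a 550-fold lower number from compound 1 to compound 2 (2.74 log units; beyond the scatter), concerns a branched chain against an aromatic ring, not one ring against another. Compound 3 keeps an aromatic ring on the carbonyl, so a number near compound 2, perhaps somewhat higher, is expected. Compound 3 is estimated at 30 nM in this assay, within 8 nM to 150 nM. The expected step is a 2.5-fold higher number from compound 2 to compound 3 (0.40 log units; beyond the scatter).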

Compound 3, half-maximal effective concentration: 47 nM
Compound 3: the middle estimate sits 1.6-fold (0.19 log units) below what was measured, within the range that was stated.
By their numbers in this assay, from the lowest: compound 2; then compound 3; then compound 1.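

In this assay, a low number does not depend on the 3-cyanophenyl group alone: 4-bromophenyl in its place gives a 3.9-fold higher number from compound 2 to compound 3 (0.59 log units; beyond the scatter) and so loses only a little, while a 140-fold lower number from compound 1 to compound 3 (2.15 log units; beyond the scatter) shows that a second aromatic ring also lies far below the isopropyl compound. The swap changes both the substituent and its place on the ring, so the step cannot be assigned to either change alone. Nothing available here explains the difference between these two rings. Still open, on these data alone, is how 4-cyanophenyl or 3-bromophenyl would compare, and whether a ring carrying an amine or a carboxylic acid would stay close to compound 2.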